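The source may hold more compounds than are shown below. What is called first, only, known or untested is meant among the compounds shown, and "the series" means these compounds.

Measured so far:
compound 1 `CC1C(=O)N=C(NC(=O)Nc2cccc(Cl)c2)N1C` — 1300 nM
compound 2 `CCN1CC(=O)N=C1NC(=O)Nc1cccc(Cl)c1` — 180 nM

In an assay on membranes from brain for displacement of a labelled ligand from metabotropic glutamate receptor 5 (Rattus norvegicus) (on this read-out lower numbers stand for stronger inhibition and higher numbers for weaker inhibition), compound 2 gives 180 nM, the lower of the two numbers; the value of compound 1 lies above it by a gap beyond the usual scatter. Within the data shown here, no single-point step between these two compounds is available, since they differ in more than one place.

Compound 3 `CCN1C(NC(=O)Nc2cccc(Cl)c2)=NC(=O)C1C` is not yet measured. It differs from compound 2 by methyl in place of hydrogen on a saturated ring carbon — methyl in place of hydrogen on a saturated ring carbon. Among the measured compounds shown here, no measured pair isolates this change, so the expected step is small, near the scatter, in either direction. Compound 3 is estimated at 250 nM (range 80 nM to 800 nM), an expected step of a 1.4-fold higher number from compound 2 to compound 3 (0.14 log units; within the scatter).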

Compound 3, half-maximal inhibitory concentration: 320 nM
Compound 3: middle estimate off by 1.3-fold (0.11 log units), on the low side; the measured number falls inside the stated range.
By their numbers in this assay, from the lowest: compounds 2 and 3 (each within the scatter of the next); then compound 1.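

In this assay, methyl in place of hydrogen on a saturated ring carbon leaves the number within the scatter (a 1.8-fold higher number from compound 2 to compound 3 (0.25 log units; within the scatter)), so this position accepts a methyl group in the presence of the ethyl group on the ring nitrogen. Methyl in place of hydrogen on a saturated chain carbon bound to an amine nitrogen in a ring gives a step beyond the scatter (a 4.1-fold lower number from compound 1 to compound 3 (0.61 log units; beyond the scatter)), the larger effect of the two single changes. No measurement available explains either step.

Going by these compounds, whether a propyl group on the ring nitrogen extends this step remains open. So does whether an ethyl or phenyl group is accepted on the saturated ring carbon.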